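Rearranging the amine: ethylamino versus dimethylamino on the core

This account rests on a few compounds, and the source may have more. Where it says the series, first, only, none or still open, it means among the compounds named here.

Compound 1 `COc1ccccc1-c1cc(C2CCNC2)ccc1Cl`: 770 nM
Compound 2 `CNCc1ccc(Cl)c(-c2ccccc2OC)c1`: 2400 nM
Compound 3 `CCNCc1ccc(Cl)c(-c2ccccc2OC)c1`: > 10000 nM

These three compounds share one core and differ only in the basic group carried on it. In an assay on isolated protein for binding affinity to 5-hydroxytryptamine receptor 1E (Homo sapiens) (a higher number here means a weaker inhibitor, a lower number a stronger inhibitor), compound 1 gives 770 nM. In this assay compound 2 gives 2400 nM. For the measured compounds named here, for compound 3 the value > 10000 nM is a limit of the assay, not a number; compound 3 is the one compound that sits at the limit of > 10000 nM in this assay, at which 1 of the 3 values shown sits, and is therefore the weakest of the three by the numbers that exist. The measured steps all point the same way: a 3.1-fold higher number from compound 1 to compound 2 (0.49 log units; beyond the scatter), an at least 12-fold higher number from compound 1 to compound 3 (1.11 log units; beyond the scatter) and an at least 4.1-fold higher number from compound 2 to compound 3 (0.61 log units; beyond the scatter).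

Compound 4 `COc1ccccc1-c1cc(CN(C)C)ccc1Cl` is not yet measured. It differs from compound 3 in that (dimethylamino in place of ethylamino on a saturated chain carbon bound to an aromatic carbon). No measured step matches this change, since every step shown replaces or extends the group rather than moving its carbons. The closest guide is that the step from compound 2 to compound 3 was already an at least 4.1-fold higher number from compound 2 to compound 3 (0.61 log units; beyond the scatter), and that compound 3 starts at the limit. Compound 4 is therefore expected to stay near that limit, with a step that the limit leaves unreadable from compound 3 to compound 4. The estimate for compound 4 is 12000 nM, ranging from 3000 nM to 40000 nM.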

Compound 4, inhibition constant: 4100 nM
Compound 4: the middle estimate sits 2.9-fold (0.47 log units) above what was measured; measured number inside the range.
By their numbers in this assay, from the lowest: compound 1; then compounds 2 and 4 (each within the scatter of the next). At a limit, above all of these: compound 3.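

Rearranging the same carbons on the amine changes the result in this assay: dimethylamino in place of ethylamino gives an at least 2.4-fold lower number from compound 3 to compound 4 (0.38 log units; beyond the scatter). Compound 3 stands only as a limit of the assay, not a number: the limit of > 10000 nM in this assay, at which 1 of the 4 values shown sits. Methyl in place of hydrogen on an amine nitrogen gives a 1.7-fold higher number from compound 2 to compound 4 (0.23 log units; within the scatter), so this added methyl, unlike the one that turns methylamino into ethylamino, shows no change beyond the scatter, while (dimethylamino)methyl in place of pyrrolidin-3-yl still gives a 5.3-fold higher number from compound 1 to compound 4 (0.73 log units; beyond the scatter).

From the compounds shown here alone, the full size of the step from ethylamino to dimethylamino stays open, since one end of it is only a limit. Going by these compounds, how a diethylamino group or a piperidine ring on the same carbon would compare with dimethylamino also remains open.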